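The compounds below may be only part of what the source reports. "The series", "measured", "known", "first", "only" and "open" are said of these compounds alone.

Compound 3 `CC(=O)Nc1cccc(-c2ccc(C(O)(c3c[nH]cn3)C3CC3)cc2)c1` gives 45 nM in an assay on isolated protein for inhibition of steroid 17-alpha-hydroxylase/17,20 lyase (Homo sapiens) (on this read-out higher numbers stand for weaker inhibition and lower numbers for stronger inhibition), the second highest of three numbers; compound 2 `CC(=O)Nc1cccc(-c2ccc(C(C)(O)c3c[nH]cn3)cc2)c1` gives 38 nM, within the scatter of compound 3. In this assay compound 1 `CC(=O)Nc1ccc(-c2ccc(C(O)(c3c[nH]cn3)C(C)C)cc2)cc1` gives 120 nM; it differs from compound 3 in two places. Compound 4 `CC(=O)Nc1cccc(-c2ccc(C(O)c3c[nH]cn3)cc2)c1` carries hydrogen in place of cyclopropyl on a saturated chain carbon bound to two aromatic carbons and an oxygen on a saturated carbon. Going by the values given here, the single measured step at the same place, a 1.2-fold higher number from compound 2 to compound 3 (0.07 log units; within the scatter), shows that exchanging methyl for cyclopropyl left the number within the scatter. Among the compounds with values here, no measured step removes the group altogether, so the expectation in this assay rests on that step alone, and only a modest shift, if any, is expected, a 1.4-fold higher number from compound 3 to compound 4 (0.16 log units; within the scatter). Compound 4 is therefore estimated at 65 nM, with a range from 20 nM to 220 nM.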

Compound 4, half-maximal inhibitory concentration: 77 nM
For compound 4 the middle estimate is 1.2-fold (0.07 log units) below the measured one; the range from low to high includes it.
By their numbers in this assay, from the lowest: compounds 2, 3, 4 and 1 (each within the scatter of the next, the first and the last beyond it).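

With hydrogen in place of cyclopropyl on this saturated chain carbon, this assay gives a 1.7-fold higher number from compound 3 to compound 4 (0.23 log units; within the scatter). Going by these compounds alone, with hydrogen in place of methyl at the same place, it gives a 2.0-fold higher number from compound 2 to compound 4 (0.31 log units; beyond the scatter), so losing the carbon group altogether costs little here, and only the step from methyl is beyond the scatter. Nothing measured offers a reason for these shifts. The compounds shown leave open whether a longer chain, such as butyl, or an amine at this place would shift the number further.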